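Fluorophenyl Variant in a Weak Aryl-Substituted Series

The source may report more compounds than this note shows. Statements on the series, on what has been measured and on what is new or still open speak of the compounds shown alone.

Compound 3, `COC(=O)CC/C(C)=C/Cc1c(OC)c(C)c2c(c1OCC#CCN1CCN(c3ccc(O)cc3)CC1)C(=O)OC2`, gives 46100 nM in a functional assay on SH-SY5Y cells (Homo sapiens) for inhibition, read by sulforhodamine B assay; a lower number here means a stronger inhibitor, a higher number a weaker inhibitor. Compound 1, `COC(=O)CC/C(C)=C/Cc1c(OC)c(C)c2c(c1OCC#CCN1CCN(c3ccc(C)cc3)CC1)C(=O)OC2`, gives 37700 nM, and compound 2, `COC(=O)CC/C(C)=C/Cc1c(OC)c(C)c2c(c1OCC#CCN1CCN(c3ccc(C#N)cc3)CC1)C(=O)OC2`, gives 37800 nM; the steps of a 1.2-fold higher number from compound 1 to compound 3 (0.09 log units; within the scatter) and a 1.2-fold higher number from compound 2 to compound 3 (0.09 log units; within the scatter) both lie within the scatter, as does a 1.0-fold higher number from compound 1 to compound 2 (0.00 log units; within the scatter). Compound 4, `COC(=O)CC/C(C)=C/Cc1c(OC)c(C)c2c(c1OCC#CCN1CCN(c3ccccc3F)CC1)C(=O)OC2`, carries 2-fluorophenyl in place of 4-hydroxyphenyl on an amine nitrogen in a ring. Among the compounds with values here, all three measured steps alter only the group on the aromatic ring attached to the ring nitrogen, and none moved the number beyond the scatter, so the change to compound 4, which again alters only that ring, is expected to give no step beyond the scatter in this assay. Compound 4 is therefore estimated at 40000 nM, within a range of 15000 nM to 100000 nM. The expected step is a 1.2-fold lower number from compound 3 to compound 4 (0.06 log units; within the scatter).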

Compound 4, half-maximal inhibitory concentration: 35800 nM
Beside the measured number, compound 4's estimate is 1.1-fold (0.05 log units) above it, and the stated range covers the measured number.
By their numbers in this assay, from the lowest: compounds 4, 1, 2 and 3 (each within the scatter of the next).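

In this assay, the flat response at this amine nitrogen now extends to 2-fluorophenyl, whose substituent is not at the 4-position and which has 0 hydrogen-bond donors: the steps of a 1.3-fold lower number from compound 3 to compound 4 (0.11 log units; within the scatter) and a 1.1-fold lower number from compound 2 to compound 4 (0.02 log units; within the scatter) and a 1.1-fold lower number from compound 1 to compound 4 (0.02 log units; within the scatter) all lie within the scatter. Nothing available here accounts for this flat response. Going by these compounds, whether an amine, a carboxylic acid or a longer chain on this aromatic ring would move the number beyond the scatter remains open. So does whether changes elsewhere on the shared core would do so.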